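The compounds below may be only part of what the source reports. "The series", "measured", "known", "first", "only" and "open" are said of these compounds alone.

In a functional assay for inhibition, with Homo sapiens as the target (a lower number here means a stronger inhibitor, a higher number a weaker inhibitor), compound 1 (`O=C(O)CCCCCCCCCn1nc(-c2ccccc2)c(-c2ccccc2)c1-c1ccccc1`) gives 5500 nM. Compound 2 (`CC(C)(C)OC(=O)COCCCCCCn1nc(-c2ccccc2)c(-c2ccccc2)c1-c1ccccc1`) gives > 62000 nM, which is a limit of the assay and not a number. Compound 3 (`NC(=O)CCCCCCCCn1nc(-c2ccccc2)c(-c2ccccc2)c1-c1ccccc1`) differs from compound 2 as follows: 2-carbamoylethyl in place of (tert-butoxycarbonyl)methoxy on a saturated chain carbon, six bonds along the chain from an aromatic nitrogen. Thus 2-carbamoylethyl stands in place of (tert-butoxycarbonyl)methoxy on a saturated chain carbon, six bonds along the chain from an aromatic nitrogen. Among the measured compounds shown here, one measured step bears on this change: an at least 11-fold higher number from compound 1 to compound 2 (1.05 log units; beyond the scatter), which brought in the same (tert-butoxycarbonyl)methoxy group. Removing that group is therefore expected to lower the number in this assay by a moderate step. Compound 1, at 5500 nM, carries 3-carboxypropyl rather than 2-carbamoylethyl, so compound 3 is expected to recover only part of that loss. The expected change is an at least 3.1-fold lower number from compound 2 to compound 3 (0.49 log units; beyond the scatter). Compound 3 is estimated at 20000 nM, within an expected range of 6000 nM to 62000 nM.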

Compound 3, half-maximal inhibitory concentration: 33000 nM
Compound 3: middle estimate off by 1.7-fold (0.22 log units), on the low side; low and high end bracket the measured number.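

In this assay, replacing (tert-butoxycarbonyl)methoxy with 2-carbamoylethyl gives an at least 1.8-fold lower number from compound 2 to compound 3 (0.27 log units; that floor lies within the scatter), so this change at the position is not shown to lower the number beyond the usual variation. Compound 2 stands only at a limit of the assay, which is not a number: the limit of > 62000 nM in this assay, at which 1 of the 3 values shown sits.

Carbamoyl in place of carboxymethyl gives a 6.0-fold higher number from compound 1 to compound 3 (0.78 log units; beyond the scatter), which shows that the chain ending in carbamoyl does not match the carboxylic acid chain of compound 1 in this assay.

The compounds shown leave open whether this step follows the end group or the chain, since the two differ in both. On these data alone, how a carboxylic acid on the chain of compound 3, an amine or a longer chain ending in carbamoyl would read in this assay also remains open.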